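The compounds below may be only part of what the source reports. "The series", "measured", "known", "first", "only" and "open" are said of these compounds alone.

In a functional assay on CHO cells for agonist activity at sphingosine 1-phosphate receptor 2 (Homo sapiens), read by fluorescence and calcium flux, with a stated time of 3 min (on this read-out higher numbers stand for weaker inhibition and lower numbers for stronger inhibition), compound 2 `Cc1cc(CO)nc(NNC(=O)Nc2cc(Cl)nc(Cl)c2)c1` reaches only the limit of the assay, > 23000 nM. Compound 1 `Cc1cc(NNC(=O)Nc2cc(Cl)nc(Cl)c2)ncc1N(C)C` likewise stops at the limit, > 23000 nM. Compound 3 `Cc1cc(NNC(=O)Nc2cc(Cl)nc(Cl)c2)ncc1-c1ccn(C)n1` also stops at the limit, > 23000 nM. For the measured compounds named here, all three values sit at the limit of > 23000 nM in this assay, at which 3 of the 3 values shown sit, so the single step among them, a step that the two limits leave unreadable from compound 1 to compound 3, cannot be read in size or direction. Compound 4 `Cc1cc(NNC(=O)Nc2cc(Cl)nc(Cl)c2)nc(-c2ccc(F)cc2)c1` differs from compound 2 by 4-fluorophenyl in place of hydroxymethyl on an aromatic carbon. Going by the values given here, no measured step bears on this exchange; every value shown is a limit. Compound 4 is therefore expected to stay at the limit in this assay, with an estimate of 30000 nM and a range from 12000 nM to 80000 nM. The expected step is a step that the limit leaves unreadable from compound 2 to compound 4, none beyond the scatter.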

Compound 4, half-maximal inhibitory concentration: > 23000 nM
Compound 4 was reported as a limit; the forecaster's own chance of this, stated with the estimate: 85%; the middle value is on the limit's open side.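

Compound 4, like compound 2, stands at a limit, so no step can be read between them: the limit of > 23000 nM in this assay, at which 4 of the 4 values shown sit. The compounds shown leave open which changes to the shared core, if any, would give a measurable value in this assay.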